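Ester chain step from compound 2 to compound 4

The compounds below may be only part of what the source reports. "The series", "measured", "known", "first", "only" and "open" are said of these compounds alone.

In an ADME assay on a cell-free system (plasma, Homo sapiens) for metabolic stability, read by LC-MS (a lower number here means that the compound disappears faster, a higher number that the compound lasts longer), compound 2 (`NCc1ccc(C(=O)Nc2ccncc2F)cc1-c1cccc(C(=O)OCC2CC2)c1`) gives 0.3 h. Compound 1 (`CCCCOC(=O)c1cccc(-c2cc(C(=O)Nc3ccncc3)ccc2CN)c1`) gives 0.367 h, within the scatter of compound 2. Compound 3 (`NCc1ccc(C(=O)Nc2ccncc2)cc1-c1cccc(C(=O)OCc2ccccc2)c1`) gives 1.07 h, beyond the scatter from compound 2.

Compound 4 (`CCCOC(=O)c1cccc(-c2cc(C(=O)Nc3ccncc3F)ccc2CN)c1`) is reached from compound 2 by one change: ethyl in place of cyclopropyl on a saturated chain carbon bound to an oxygen next to a carbonyl group. Cut one bond further out, this reads cyclopropylmethyl to propyl.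

Going by the values given here, the only measured step at this place is a 2.9-fold higher number from compound 1 to compound 3 (0.46 log units; beyond the scatter), with phenyl in place of propyl. That step is modest, and compound 4 gains no phenyl, so it offers little guide to a swap from cyclopropyl to ethyl. The closest guide is compound 1 at 0.367 h, which carries a chain without a ring and still lies within the scatter of compound 2. No shift in either direction is therefore expected, and the estimated change is a 1.1-fold higher number from compound 2 to compound 4 (0.04 log units; within the scatter), within the scatter. For compound 4 the expected half-life is 0.33 h, with an estimated range of 0.17 h to 0.65 h.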

Compound 4, half-life: 0.317 h
Estimate against measurement, compound 4: 1.0-fold (0.02 log units) above, and the stated range covers the measured number.
By their numbers in this assay, from the lowest: compounds 2, 4 and 1 (each within the scatter of the next); then compound 3.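

In this assay, ethyl in place of cyclopropyl on a saturated chain carbon bound to an oxygen next to a carbonyl group gives a 1.1-fold higher number from compound 2 to compound 4 (0.02 log units; within the scatter), so at this place the three-membered ring can give way to an open chain with a step that stays within the scatter. Going by these compounds alone, the only earlier step here, a 2.9-fold higher number from compound 1 to compound 3 (0.46 log units; beyond the scatter) with phenyl in place of propyl, lies beyond the scatter, so the two steps together show that this place does not answer alike to every exchange. Nothing available accounts for either step.

On these data alone, the phenyl step stands on the core of compound 1 alone, and whether it carries over to the core of compound 4 stays open. Also open, as far as these compounds go, is how a longer chain, a branched isopropyl group or a chain bearing an amine would read at this place.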